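From 2,5-difluorophenyl to 3,5-difluorophenyl in compound 4

A few compounds are considered here, and "the series" means these few. Any claim that something is new, unique, unknown or untested is made for them only; others in the source may bear on it.

Values so far in an ADME assay on MT4 cells (Homo sapiens) for cytotoxicity, read by MTT assay; a lower number here means that less compound is tolerated, a higher number that more compound is tolerated
- Compound 1 `O=C1c2ccccc2C(=O)N1CCOC(=S)N(C(=O)c1cccc([N+](=O)[O-])c1)c1ccc(Cl)cc1` gives 18000 nM
- Compound 2 `O=C1c2ccccc2C(=O)N1CCOC(=S)N(C(=O)c1ccc(F)cc1F)c1ccc(Cl)cc1` gives 52000 nM
- Compound 3 `O=C1c2ccccc2C(=O)N1CCOC(=S)N(C(=O)c1cc(F)ccc1F)c1ccc(Cl)cc1` gives 54000 nM

Compound 3 shares the upper end of this small set, and only compound 1 lies apart from it. The measured steps show this: a 1.0-fold higher number from compound 2 to compound 3 (0.02 log units; within the scatter) stays within the scatter, whereas a 3.0-fold higher number from compound 1 to compound 3 (0.48 log units; beyond the scatter) goes beyond it, as does a 2.9-fold higher number from compound 1 to compound 2 (0.46 log units; beyond the scatter).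

Compound 4 `O=C1c2ccccc2C(=O)N1CCOC(=S)N(C(=O)c1cc(F)cc(F)c1)c1ccc(Cl)cc1` has not yet been measured. Its change is 3,5-difluorophenyl in place of 2,5-difluorophenyl on a carbonyl carbon, with 3,5-difluorophenyl in place of 2,5-difluorophenyl on a carbonyl carbon. Among the measured compounds shown here, the closest guide is the one swap of a difluorophenyl group for another, a 1.0-fold higher number from compound 2 to compound 3 (0.02 log units; within the scatter). The two modest steps start from 3-nitrophenyl and bear on this change less directly. No step beyond the scatter is therefore expected in this assay, though this rests on a single comparison. The estimated step is a 1.1-fold lower number from compound 3 to compound 4 (0.03 log units; within the scatter). For compound 4 the estimated half-maximal cytotoxic concentration is 50000 nM, with an expected range from 28000 nM to 90000 nM.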

Compound 4, half-maximal cytotoxic concentration: 59000 nM
Estimate against measurement, compound 4: 1.2-fold (0.07 log units) below; low and high end bracket the measured number.
By their numbers in this assay, from the lowest: compound 1; then compounds 2, 3 and 4 (each within the scatter of the next).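

In this assay, a third placement of the two fluorines on the phenyl group at this carbonyl carbon gives no separation from the other two (a 1.1-fold higher number from compound 3 to compound 4 (0.04 log units; within the scatter); a 1.1-fold higher number from compound 2 to compound 4 (0.05 log units; within the scatter)), as both steps lie within the scatter. The 2,4-difluorophenyl, 2,5-difluorophenyl and 3,5-difluorophenyl groups therefore cannot be told apart here, which a single swap between two of them could only hint at. The modest gap from the 3-nitrophenyl compound also holds for the new group (a 3.3-fold higher number from compound 1 to compound 4 (0.52 log units; beyond the scatter)), and nothing measured on these compounds accounts for either observation.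

Going by these compounds, what remains open is whether this level holds for an unsubstituted phenyl, or for a phenyl carrying an amine or a carboxylic acid. On these data alone, the rest of the core is the same throughout, so its contribution also remains unknown.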